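The compounds below may be only part of what the source reports. "The series", "measured", "known", "first", "only" and "open" are said of these compounds alone.

Three compounds share the arylsulfonyl benzylamide motif and were examined in a physicochemical assay for solubility, in phosphate buffer, with a stated time of 24 h, at pH 7.4, tested at 100 uM; on this read-out lower numbers stand for lower solubility and higher numbers for higher solubility. Compound 1 `O=C(NCc1ccc(S(=O)(=O)c2ccccc2)cc1)c1cc2cnccc2[nH]1` gives 3000 nM in this assay. Compound 2 `O=C(NCc1ccc(S(=O)(=O)c2ccccc2)cc1)N1CCc2ccncc2C1` gives 115000 nM in this assay. Compound 3 `CCCn1cc(S(=O)(=O)c2ccc(CNC(=O)N3Cc4ccncc4C3)cc2)cn1` gives 105000 nM in this assay, and it stands second highest of the three numbers: its nearest neighbour is compound 2, whose value lies within the scatter of its own, while compound 1 sits far below it, beyond the scatter.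

Compound 4 `O=C(NCc1ccc(S(=O)(=O)N2CCC[C@@H](O)C2)cc1)N1Cc2ccncc2C1` has not yet been measured in this assay. Its difference from compound 3 is a single change: 3-hydroxypiperidin-1-yl in place of 1-propyl-1H-pyrazol-4-yl on a sulfonyl sulfur. Among the compounds with values here, no pair of measured compounds differs by this kind of swap, so no measured step can be read off directly. Compounds 2 and 3 carry different groups on the sulfonyl sulfur and still give numbers within the scatter of each other, so the expected step in this assay from compound 3 to compound 4 is a 1.4-fold higher number from compound 3 to compound 4 (0.15 log units; within the scatter), none beyond the scatter or a modest rise. Compound 4 is therefore estimated at 150000 nM, with a range of 60000 nM to 400000 nM.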

Compound 4, solubility: 216000 nM
Beside the measured number, compound 4's estimate is 1.4-fold (0.16 log units) below it; low and high end bracket the measured number.
By their numbers in this assay, from the lowest: compound 1; then compounds 3, 2 and 4 (each within the scatter of the next, the first and the last beyond it).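

In this assay, within the data shown here, the exchange on the sulfonyl sulfur gives the first step that can be read at this position: a 2.1-fold higher number from compound 3 to compound 4 (0.31 log units; beyond the scatter) when 3-hydroxypiperidin-1-yl enters in place of 1-propyl-1H-pyrazol-4-yl. The earlier compounds shown here offered no such step, and this one shows that a six-membered non-aromatic ring bearing a hydroxyl can replace a five-membered aromatic ring here with a modest rise in the number rather than a fall. Nothing measured here explains that rise.

This single step does not separate the contribution of the ring from that of the hydroxyl, and a plain piperidin-1-yl group on the same sulfur would address that question. The 3-hydroxypiperidin-1-yl group of opposite configuration at its stereocentre would show whether the defined stereocentre matters.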